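The source may hold more compounds than are shown below. What is called first, only, known or untested is meant among the compounds shown, and "the series" means these compounds.

Of the compounds shown here, two sharing one core have been measured so far. Compound 1 `C#CCN(Cc1ccc(OCc2cccc(F)c2)cc1)[C@@H](C)C(N)=O` gives 7790 nM in an assay on Sf9 cells for inhibition of Amine oxidase [flavin-containing] A (Homo sapiens), with stated times of 15 min and 60 min; on this read-out lower numbers stand for stronger inhibition and higher numbers for weaker inhibition. Compound 2 `C[C@H](NCc1ccc(OCc2cccc(F)c2)cc1Cl)C(N)=O` gives 12000 nM in this assay; this is the larger of the two numbers, but its gap to compound 1 lies within the usual scatter of repeated measurements, so the two cannot be told apart. Among the compounds with values here, compound 1 and compound 2 differ in two places, so their pair yields no single-change step.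

Compound 3 `C#CCN(Cc1ccc(OCc2cccc(F)c2)cc1Cl)[C@@H](C)C(N)=O` is the next member awaiting measurement. It is compound 2 with one change: propargyl in place of hydrogen on an amine nitrogen. Within the data shown here, no single-change step has been measured in this set, so the size of this step in this assay must be estimated without a direct precedent. The step from compound 2 to compound 3 is expected to be modest, lowering the number by about a 2.0-fold lower number from compound 2 to compound 3 (0.30 log units; within the scatter). Compound 3 is therefore estimated at 6000 nM, with a likely range from 2000 nM to 18000 nM.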

Compound 3, half-maximal inhibitory concentration: 5600 nM
Estimate against measurement, compound 3: 1.1-fold (0.03 log units) above; the range from low to high includes it.
By their numbers in this assay, from the lowest: compounds 3, 1 and 2 (each within the scatter of the next, the first and the last beyond it).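

In this assay, within the data shown here, propargyl in place of hydrogen on an amine nitrogen gives a 2.1-fold lower number from compound 2 to compound 3 (0.33 log units; beyond the scatter) and is the only single-change step here that lies beyond the usual scatter, although it is modest. Chloro in place of hydrogen on an aromatic carbon, with propargyl on the nitrogen in both compounds, gives a 1.4-fold lower number from compound 1 to compound 3 (0.14 log units; within the scatter) and so leaves that pair indistinguishable. No measurement is at hand that would explain either step.

Going by these compounds, it remains open whether a methyl group or a longer chain on that nitrogen would give a step of similar size to propargyl. On these data alone, it is also open whether bromo in place of chloro would shift the number, and whether the chloro step would keep its size with hydrogen rather than propargyl on the nitrogen.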